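A few compounds are considered here, and "the series" means these few. Any claim that something is new, unique, unknown or untested is made for them only; others in the source may bear on it.

Measured compounds:
compound 1, `CC(C)Cc1cc(-c2cccc(Cn3ccnc3)c2)c(S(=O)(=O)NC(=O)OC(C)C)s1`, half-life 0.283 h
compound 2, `CC(C)Cc1cc(-c2cccc(Cn3ccnc3)c2)c(S(=O)(=O)NC(=O)OC(C)(C)C)s1`, half-life 0.3 h

In an ADME assay on microsomes from liver (Homo sapiens) for metabolic stability, read by LC-MS, using NADPH, tested at 1 uM (a higher number here means that the compound lasts longer, a lower number that the compound disappears faster), compound 1 gives 0.283 h, and compound 2 gives 0.3 h. Going by the values given here, the one measured step, a 1.1-fold higher number from compound 1 to compound 2 (0.03 log units; within the scatter), is the only comparison available, and it leaves the two compounds indistinguishable: compound 2 stands alongside compound 1, not apart from it.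

Compound 3, `CCCC(=O)NS(=O)(=O)c1sc(CC(C)C)cc1-c1cccc(Cn2ccnc2)c1`, is not yet measured. Its change from compound 2 is propyl in place of tert-butoxy on a carbonyl carbon. This is a change of a different kind from the methyl in place of hydrogen that separates compound 1 from compound 2, so the measured step does not speak to it directly; it only shows that alteration at this end of the molecule gave a 1.1-fold higher number from compound 1 to compound 2 (0.03 log units; within the scatter). Among the compounds with values here, no measured pair replaces tert-butoxy by propyl, so no direction can be read from the data. Compound 3 is therefore expected to give no step beyond the scatter, no change at the digits printed from compound 2 to compound 3 (within the scatter). The estimate for compound 3 is 0.3 h, expected to fall between 0.15 h and 0.6 h.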

Compound 3, half-life: 0.08 h
The estimate for compound 3 lay 3.8-fold (0.57 log units) above the measured number; the measured number lies below the stated range.
By their numbers in this assay, from the lowest: compound 3; then compounds 1 and 2 (each within the scatter of the next).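

In this assay, the end of the molecule on the carbonyl carbon turns out not to be indifferent: the earlier pair had shown only that tert-butoxy and isopropoxy sit within the scatter of each other, whereas propyl in this place gives a 3.8-fold lower number from compound 2 to compound 3 (0.57 log units; beyond the scatter). The same replacement of isopropoxy gives a 3.5-fold lower number from compound 1 to compound 3 (0.55 log units; beyond the scatter), so both oxygen-linked groups part from propyl in the same direction and by a modest step, with the rest of the molecule unchanged. Nothing at hand explains this drop in half-life.

The compounds shown leave open whether the lower number follows from the loss of the oxygen on the carbonyl carbon or from the propyl chain as such, as these two differences arrive together in compound 3. A branched chain such as tert-butyl, placed directly on the carbonyl carbon, or a longer chain such as pentyl, would separate the two readings, and an amine in that place would show whether another atom bound to the carbonyl carbon behaves like the oxygen of compound 1 and compound 2.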